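Pyrimidin-2-yl replacing pyridin-2-yl on the piperazine-linked series

The source may hold more compounds than are shown below. What is called first, only, known or untested is meant among the compounds shown, and "the series" means these compounds.

Three compounds share one core. In a functional assay, read by spectrophotometry, with a stated time of 30 min, tested at 200 ug/mL (on this read-out higher numbers stand for a stronger effect at the one concentration tested and lower numbers for a weaker effect), compound 1 `O=C(CN1CCN(c2ccccc2)CC1)Nc1nc2ccccc2[nH]1` gives 62.1%, compound 2 `O=C(CN1CCN(c2ccccc2F)CC1)Nc1nc2ccccc2[nH]1` gives 70.6%, and compound 3 `O=C(CN1CCN(c2ccccn2)CC1)Nc1nc2ccccc2[nH]1` gives 76.2%, the highest of the three numbers. The gap a number 14.1 percentage points higher from compound 1 to compound 3 (beyond the scatter) is beyond the scatter, whereas a number 5.6 percentage points higher from compound 2 to compound 3 (within the scatter) is not. Compound 4 `O=C(CN1CCN(c2ncccn2)CC1)Nc1nc2ccccc2[nH]1` differs from compound 3 by pyrimidin-2-yl in place of pyridin-2-yl on an amine nitrogen in a ring. The bearing steps are a number 14.1 percentage points higher from compound 1 to compound 3 (beyond the scatter), a modest rise, and a number 5.6 percentage points higher from compound 2 to compound 3 (within the scatter), within the scatter. Compound 4 is expected to show a step of a number 1.8 percentage points higher from compound 3 to compound 4 (within the scatter), not beyond the scatter. Compound 4 is therefore estimated at 78%, between 64% and 90%.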

Compound 4, a percentage reported as activity, at one concentration (the size of the read-out at that concentration, not a potency): 81.8%
Beside the measured number, compound 4's estimate is 3.8 percentage points below it, within the range that was stated.
By their numbers in this assay, from the lowest: compounds 1, 2, 3 and 4 (each within the scatter of the next, the first and the last beyond it).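

In this assay, putting pyrimidin-2-yl in place of pyridin-2-yl on this amine nitrogen in a ring gives a step that cannot be told from scatter, a number 5.6 percentage points higher from compound 3 to compound 4 (within the scatter). Pyrimidin-2-yl does, however, separate from both remaining aromatic groups, with a number 11.2 percentage points higher from compound 2 to compound 4 (beyond the scatter) and a number 19.7 percentage points higher from compound 1 to compound 4 (beyond the scatter), whereas pyridin-2-yl separated only from phenyl. No measurement bears on why these steps arise. From the compounds shown here alone, whether a pyrazin-2-yl group on the same amine nitrogen, or an amine carried on the pyrimidin-2-yl ring, would give a higher or lower number remains open.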